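Swapping aminocarbamoyl for methyl on a shared core

The compounds below may be only part of what the source reports. "The series", "measured", "known", "first", "only" and "open" are said of these compounds alone.

Measured so far:
compound 1, `O=C(O)/C=N/Nc1nc2ccccc2s1`, which in an assay for inhibition of Indoleamine 2,3-dioxygenase 1 (Homo sapiens), with a stated time of 1 h, tested at 0.1 mM (on this read-out higher numbers stand for more inhibition at the one concentration tested (going by the name of the read-out) and lower numbers for less inhibition), gives 13%
compound 2, `NNC(=O)c1ccc2nc(NN)sc2c1`, which in this assay gives -1%

Both measured compounds share a core carrying a hydrazinyl group on the five-membered ring, and neither shows much effect in this assay. Going by the values given here, of the two numbers, compound 2 is the lower, and compound 1 stands higher by a margin that lies beyond the usual scatter of repeated measurements; with only two compounds in hand, no further pattern can be read from this.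

The next compound, compound 3, `Cc1ccc2nc(NN)sc2c1`, keeps the core of compound 2 and changes one place on the six-membered ring: methyl in place of aminocarbamoyl on an aromatic carbon. Because compound 2 gives -1% in this assay, essentially no inhibition, the starting point for this step is the lowest number seen so far. Among the compounds with values here, no comparable step has been measured, so the size of a number 6 percentage points higher from compound 2 to compound 3 (within the scatter) is an expectation only: a small shift, if any, likely upward but not clearly beyond the scatter. Compound 3 is therefore estimated to give 5% in this assay, within a range from -10% to 22%.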

Compound 3, a percentage reported as inhibition, at one concentration (the size of the read-out at that concentration, not a potency): 37%
Compound 3: middle estimate off by 32 percentage points, on the low side; the whole stated range lies below it.
By their numbers in this assay, from the lowest: compound 2; then compound 1; then compound 3.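

This result shows that the aromatic carbon on the six-membered ring of the shared core is not a silent place in this assay: methyl in place of aminocarbamoyl gives a number 38 percentage points higher from compound 2 to compound 3 (beyond the scatter). Going by these compounds alone, it is the first step here that ties a change in the read-out to a single place, and it shows that this position can take the smaller group, with 1 heavy atom and no hydrogen-bond donors or acceptors, instead of a group with 4 heavy atoms, 2 donors and 2 acceptors, while inhibition at the one concentration tested rises. Nothing measured here shows which of these differences lies behind the step.

The compounds shown leave open whether the rise comes from having methyl on this carbon or simply from losing aminocarbamoyl, a question that a plain hydrogen at the same place would help to settle. They also leave open how a longer chain such as ethyl, an amine or a carboxylic acid would read out on this carbon, and whether the same change would act alike on another core.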